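Swapping methyl for chloro on the pendant phenyl ring

The source may report more compounds than this note shows. Statements on the series, on what has been measured and on what is new or still open speak of the compounds shown alone.

Measured so far:
- compound 1, `Cc1ccc(NC(=S)NC(=O)c2cn(-c3ccccc3)nc2-c2ccc(Cl)cc2)cc1`: 2690 nM
- compound 2, `Cc1ccc(-c2nn(-c3ccccc3)cc2C(=O)NC(=S)Nc2ccc(Cl)cc2)cc1`: 3170 nM

In a functional assay on A549 cells (Homo sapiens) for inhibition, read by CCK-8 assay, with a stated time of 48 h (a higher number here means a weaker inhibitor, a lower number a stronger inhibitor), compound 1 gives 2690 nM. In this assay compound 2 gives 3170 nM, and the two numbers lie within the scatter of each other, so neither can be called the stronger inhibitor. Compound 3, `O=C(NC(=S)Nc1ccc(Cl)cc1)c1cn(-c2ccccc2)nc1-c1ccc(Cl)cc1`, is not yet measured. It differs from compound 2 by chloro in place of methyl on an aromatic carbon. Among the measured compounds shown here, no pair of measured compounds shows what this single change does. The step from compound 2 to compound 3 in this assay is therefore expected to stay within the scatter, in either direction, as a 1.1-fold lower number from compound 2 to compound 3 (0.02 log units; within the scatter). Compound 3 is estimated at 3000 nM, in a range from 1200 nM to 7500 nM.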

Compound 3, half-maximal inhibitory concentration: 3150 nM
Compound 3: middle estimate off by 1.1-fold (0.02 log units), on the low side; the measured number falls inside the stated range.
By their numbers in this assay, from the lowest: compounds 1, 3 and 2 (each within the scatter of the next).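

In this assay, the change from 4-methylphenyl to 4-chlorophenyl can now be read at two different places on the molecule: a 1.0-fold lower number from compound 2 to compound 3 (0.00 log units; within the scatter), and a 1.2-fold higher number from compound 1 to compound 3 (0.07 log units; within the scatter). Both steps lie within the scatter, so chloro in place of methyl shows no measurable effect at either place. Nothing available here offers an explanation for this result. Methyl and chloro are the only groups compared at these places, so they show only that these two are interchangeable in this assay. Going by these compounds, whether an amine or a carboxylic acid there would shift the number remains open.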